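Moving from a benzyl to a 4-methylphenyl group

The compounds below may be only part of what the source reports. "The series", "measured", "known", "first", "only" and "open" are said of these compounds alone.

Compound 1 `Cc1nc(COc2ccc(/C=C3\SC(=O)NC3=O)cc2)cs1` gives 38.9% in a functional assay on the whole organism (strain Wistar) with Rattus norvegicus as the target, with a stated time of 15 days, at a dose of 100 mg/kg by the oral route; on this read-out lower numbers stand for a weaker effect and higher numbers for a stronger effect at the one dose given. Compound 2 `O=C1NC(=O)/C(=C/c2ccc(OCCSc3nnc(-c4ccccc4)[nH]3)cc2)S1` gives 38.9%. Compound 3 `O=C1NC(=O)/C(=C/c2ccc(OCCSc3nnc(Cc4ccccc4)[nH]3)cc2)S1` gives 41.9%.

Compound 3 has the highest number of the three, but its values lie within the scatter of compound 1 and compound 2 alike, so none of the three can be set apart. Compound 4 `Cc1ccc(-c2nnc(SCCOc3ccc(/C=C4\SC(=O)NC4=O)cc3)[nH]2)cc1` differs from compound 3 in one place: 4-methylphenyl in place of benzyl on an aromatic carbon. For the measured compounds named here, one measured step bears on this position, a number 3 percentage points higher from compound 2 to compound 3 (within the scatter), which stayed within the scatter. Swapping one seven-carbon group for another at the same place is therefore expected to leave the number roughly where it is, with no step beyond the scatter, so a number 1.9 percentage points lower from compound 3 to compound 4 (within the scatter) is the expectation. Compound 4 is estimated at 40%, between 30% and 50%.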

Compound 4, a percentage reported as activity, at one dose (the size of the read-out at that dose, not a potency): 54%
Estimate against measurement, compound 4: 14 percentage points below; measured number above the stated range.
By their numbers in this assay, from the lowest: compounds 1, 2 and 3 (each within the scatter of the next); then compound 4.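

Even with the same atoms joined differently, the group on this aromatic carbon, between two ring nitrogen atoms, changes the result in this assay: 4-methylphenyl in place of benzyl gives a number 12.1 percentage points higher from compound 3 to compound 4 (beyond the scatter), the first change at this position to pass the scatter. Methyl in place of hydrogen on the aromatic ring also gives a number 15.1 percentage points higher from compound 2 to compound 4 (beyond the scatter), so a single added methyl is enough to separate two compounds. Nothing shown explains why these numbers rise.

Going by these compounds, whether a chlorine, a methoxy group or a carboxylic acid in place of that methyl would do the same remains open. So does the effect of a longer chain, such as 4-ethylphenyl.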